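From compound 3 to compound 4: one side group exchanged

The compounds below may be only part of what the source reports. "The series", "measured", "known", "first", "only" and "open" are said of these compounds alone.

Among the compounds with values here, in a functional assay on COR-L23 cells (Homo sapiens) for antiproliferative activity, read by CellTiter-Glo, with a stated time of 72 h (on this read-out higher numbers stand for weaker inhibition and lower numbers for stronger inhibition), compound 3 (`C[C@@H](c1ccc(NC(=O)N2CC(c3cncc(N)c3)C2)cc1)N1Cc2ccccc2C1=O`) gives 130 nM, the highest number of the three measured so far, which makes it the weakest inhibitor among them. Compound 2 (`C[C@@H](c1ccc(NC(=O)N2CC(c3ccc(N)nc3)C2)cc1)N1Cc2ccccc2C1=O`) gives 19 nM, and compound 1 (`C[C@H](NC(=O)C1CCOCC1)c1ccc(NC(=O)N2CC(c3cccnc3)C2)cc1`) gives 58 nM.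

Compound 4 (`C[C@H](NC(=O)C1CCOCC1)c1ccc(NC(=O)N2CC(c3cncc(N)c3)C2)cc1`) keeps the 5-aminopyridin-3-yl group of compound 3 and changes a different part of the molecule: a group of 9 heavy atoms (6 carbon, 1 nitrogen, 2 oxygen; one six-membered non-aromatic ring with 1 hetero atom) in place of a group of 10 heavy atoms (8 carbon, 1 nitrogen, 1 oxygen; one five-membered non-aromatic ring with 1 hetero atom, one six-membered aromatic ring of carbon only), on a saturated chain carbon bound to an aromatic carbon and a saturated chain carbon. The incoming ((oxan-4-yl)carbonyl)amino group is already present in compound 1.

Within the data shown here, only one measured step links two compounds that differ in a single place: a 6.8-fold higher number from compound 2 to compound 3 (0.84 log units; beyond the scatter). That step is clear, but it concerns the amino-bearing ring, which stays the same here, so it does not measure the exchange itself. Compound 1 gives 58 nM with the incoming group, a lower number than compound 3 shows. However, compound 1 also lacks the amino group of compound 3, so it is only a loose guide.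

With so little evidence, no step beyond the scatter is expected in this assay, and the estimated change is a 1.2-fold higher number from compound 3 to compound 4 (0.06 log units; within the scatter). Compound 4 is expected at 150 nM, with an estimated range of 50 nM to 450 nM.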

Compound 4, half-maximal inhibitory concentration: 970 nM
Compound 4: the middle estimate sits 6.5-fold (0.81 log units) below what was measured; the whole stated range lies below it.
By their numbers in this assay, from the lowest: compound 2; then compound 1; then compound 3; then compound 4.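

In this assay, the exchange on the saturated chain carbon bound to an aromatic carbon and a saturated chain carbon turns out to matter, with a 7.5-fold higher number from compound 3 to compound 4 (0.87 log units; beyond the scatter), so when the 5-aminopyridin-3-yl group is present, the ((oxan-4-yl)carbonyl)amino group gives a much weaker result than the group it replaces. Within the data shown here, the other new step holds that ((oxan-4-yl)carbonyl)amino group fixed and adds one amino group, in place of hydrogen on an aromatic carbon, and it gives a 17-fold higher number from compound 1 to compound 4 (1.22 log units; beyond the scatter), which shows for the first time that the presence of this amino group, and not only its place on the ring, can change the number strongly. Nothing measured here explains why either step goes the way it does.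

As far as these compounds go, it remains open whether adding the amino group costs as much when the group of compound 3 sits on the chain carbon, since the size of this step has been read with only one partner. From the compounds shown here alone, it also remains open whether a methoxy group or a fluorine in place of that amino group, or an acetylamino group on the chain carbon, would give numbers closer to those of compound 1 or those of compound 4.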